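This account rests on a few compounds, and the source may have more. Where it says the series, first, only, none or still open, it means among the compounds named here.

The account begins with compound 1, `CC(C(=O)N1CCN(c2ccccc2)CC1)N1C(=O)CCC1=O`, tested in a functional assay on the whole organism (strain Swiss) with Mus musculus as the target, in the maximal electroshock model, with a stated time of 1 h, at a dose of 100 mg/kg by the intraperitoneal route; on this read-out lower numbers stand for a weaker effect and higher numbers for a stronger effect at the one dose given. In this assay compound 1 gives 0%. Two related compounds were measured alongside it. Compound 2, `CC(C(=O)N1CCN(c2ccccc2F)CC1)N1C(=O)CCC1=O`, gives 0% in this assay, and compound 3, `CC(C(=O)N1CCN(c2ccc(F)cc2)CC1)N1C(=O)CCC1=O`, gives 0%. Compound 1 stands level with compounds 2 and 3: the step from compound 1 to compound 2 is no change at the digits printed from compound 1 to compound 2 (within the scatter), the step from compound 1 to compound 3 is no change at the digits printed from compound 1 to compound 3 (within the scatter), and between the two fluorinated compounds there is no change at the digits printed from compound 2 to compound 3 (within the scatter). None of the three shows any effect in this model at the dose tested.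

The unmeasured compound 4 is `CC(C(=O)N1CCN(c2cccc(Cl)c2)CC1)N1C(=O)CCC1=O`. Its difference from compound 1 is chloro in place of hydrogen on an aromatic carbon, a change that, seen one bond further out, reads as phenyl to 3-chlorophenyl. Among the measured compounds shown here, the steps that bear on it are those in which a halogen enters the same ring, no change at the digits printed from compound 1 to compound 2 (within the scatter) and no change at the digits printed from compound 1 to compound 3 (within the scatter), both flat. A different halogen entering that ring gives no reason in these data to expect anything else. On that basis the expected step from compound 1 to compound 4 in this assay is no change at the digits printed from compound 1 to compound 4 (within the scatter), none beyond the scatter. Compound 4 is therefore estimated at 0%, within a range from 0% to 15%.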

Compound 4, a percentage reported as activity, at one dose (the size of the read-out at that dose, not a potency): 50%
Beside the measured number, compound 4's estimate is 50 percentage points below it; the whole stated range lies below it.
By their numbers in this assay, from the lowest: compounds 1, 2 and 3 (each within the scatter of the next); then compound 4.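

Going from phenyl to 3-chlorophenyl is the one change here that moves the read-out in this assay, and it gives a number 50 percentage points higher from compound 1 to compound 4 (beyond the scatter) with the shared core left as it was. Set against the fluorinated compounds, the result is a number 50 percentage points higher from compound 2 to compound 4 (beyond the scatter) and a number 50 percentage points higher from compound 3 to compound 4 (beyond the scatter), so a halogen on this ring is not enough in itself, and among these compounds the effect appears only with 3-chlorophenyl. Nothing in the material at hand accounts for this gain.

The compounds shown do not separate the identity of the halogen from its place on the ring, since fluoro appears only as 2-fluorophenyl and 4-fluorophenyl, while chloro appears only as 3-chlorophenyl. Going by these compounds, it also stays open whether bromo or trifluoromethyl in place of the chloro would keep, raise or lose the effect, and whether compound 4 would hold it at other doses or times.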